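Chloro for Fluoro on the Pendant Ring: a Clearance Estimate

The compounds below may be only part of what the source reports. "The series", "measured", "known", "first", "only" and "open" are said of these compounds alone.

Compound 1 `COc1ccc(S(=O)(=O)c2cnc3c(F)cccc3c2-c2cccc(F)c2)cc1` and compound 2 `COc1ccc(S(=O)(=O)c2cnc3c(F)cccc3c2-c2cccc(Cl)c2)cc1` share one core, and compound 3 `O=S(=O)(c1ccc(F)c(Cl)c1)c1cnc2c(F)cccc2c1-c1ccc(F)cc1` and compound 4 `O=S(=O)(c1ccc(F)c(Cl)c1)c1cnc2c(F)cccc2c1-c1ccc(Cl)cc1` share another; how the two cores differ is not broken down here. In an ADME assay on microsomes from liver (Homo sapiens) for metabolic stability, tested at 2.5 uM (a lower number here means slower removal, a higher number faster removal of the compound), compound 1 gives 3.03 mL/min and compound 2 gives 2.75 mL/min, and the step of a 1.1-fold lower number from compound 1 to compound 2 (0.04 log units; within the scatter) came from the change (chloro in place of fluoro on an aromatic carbon). In this assay compound 3 gives 0.19 mL/min, the lowest of the three numbers, with both of its steps to the other two compounds beyond the scatter. Compound 4 arises from compound 3 by the change (chloro in place of fluoro on an aromatic carbon). The two changes are the same kind of change, though the place differs: meta to a large group in the first pair, para to a large group in the second. Because the earlier step of a 1.1-fold lower number from compound 1 to compound 2 (0.04 log units; within the scatter) lay within the scatter, a step of similar size, a 1.1-fold higher number from compound 3 to compound 4 (0.02 log units; within the scatter), is expected here. Compound 4 is therefore estimated at 0.2 mL/min in this assay, expected to fall between 0.1 mL/min and 0.45 mL/min.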

Compound 4, intrinsic clearance in a liver preparation (reported as CLH), per the amount of preparation that the assay uses: 0.01 mL/min
Compound 4: the middle estimate sits 20-fold (1.30 log units) above what was measured, and the stated range ends above it.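

In this assay, the change from 4-fluorophenyl to 4-chlorophenyl gives a 19-fold lower number from compound 3 to compound 4 (1.28 log units; beyond the scatter), a large step on the core shared by compound 3 and compound 4. The size of a step for this change therefore did not carry from one core to the other in this series, and the earlier result was no safe guide to the new one: the same change on two cores in this assay, a 1.1-fold lower number (0.04 log units; within the scatter) from compound 1 to compound 2 and a 19-fold lower number (1.28 log units; beyond the scatter) from compound 3 to compound 4, 17-fold (1.24 log units) apart, beyond the scatter of two such steps. This does not show why the steps differ, since the two pairs differ both in the core and in the place of the change, and two steps cannot separate these, nor can they say how the change would behave on any further core.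

The compounds shown leave open whether chloro in place of fluoro, set at one and the same place, would give steps of different size on the two cores. They also leave open how a nitrile or an amine at that place would compare on the core of compound 3.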